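Fluoro for Chloro in a Series Resting at the Limit

The source may hold more compounds than are shown below. What is called first, only, known or untested is meant among the compounds shown, and "the series" means these compounds.

Compound 1 `CCc1cc(Cc2cccc(OC)c2)c(=O)n(CC(=O)Nc2ccc(I)cc2)n1`: in an assay on HL-60 cells for agonist activity at N-formyl peptide receptor 3 (Homo sapiens), read by calcium flux (on this read-out higher numbers stand for an effect only at larger amounts of compound and lower numbers for an effect already at smaller amounts), compound 1 gives > 50000 nM, which is a limit of the assay rather than a number.
Compound 2 `COc1ccc(Cc2cc(-c3cccs3)nn(CC(=O)Nc3ccc(Br)cc3)c2=O)cc1`: in this assay compound 2 gives > 50000 nM, again a limit.
Compound 3 `COc1ccc(Cc2cc(-c3ccc(Cl)cc3)nn(CC(=O)Nc3ccc(Br)cc3)c2=O)cc1`: in this assay compound 3 gives > 50000 nM, also a limit.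

Compound 3 therefore stands at the limit of the assay, and so do the other two compounds shown, because of the limit of > 50000 nM in this assay, at which 3 of the 3 values shown sit. Among the measured compounds shown here, the only measured step with a single structural change, a step that the two limits leave unreadable from compound 2 to compound 3, starts and ends at that limit and cannot be read in size or direction.

Compound 4 `COc1ccc(Cc2cc(-c3ccc(F)cc3)nn(CC(=O)Nc3ccc(Br)cc3)c2=O)cc1` differs from compound 3 in one place: fluoro in place of chloro on an aromatic carbon. For the measured compounds named here, no measured step bears on a fluoro-for-chloro exchange, and the one step that exists, from compound 2 to compound 3, gives no size to lean on. The expectation for compound 4 is therefore that it stays at or near the limit, with an estimated step of a number no higher from compound 3 to compound 4 (the limit leaves the size open) that is not expected to rise beyond the scatter. Compound 4 is estimated at 50000 nM, within a range of 15000 nM to 200000 nM, most likely reported again only as a limit.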

Compound 4, half-maximal effective concentration: > 50000 nM
Compound 4 gave a limit, no number (the forecaster's own chance of this, stated with the estimate: 85%); the middle value lies on the limit itself.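

The steps among compound 2, compound 3 and compound 4 cannot be read, since each compound gives a limit in this assay rather than a number: the limit of > 50000 nM in this assay, at which 4 of the 4 values shown sit.

The compounds shown leave open whether 4-fluorophenyl and 4-chlorophenyl differ at all, and which structures would give a real number in this assay.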